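A few compounds are considered here, and "the series" means these few. Any claim that something is new, unique, unknown or untested is made for them only; others in the source may bear on it.

Series notes. Compound 1 `CS(=O)(=O)c1ccc(-c2nc(SCCCOC(=O)/C=C/c3ccc(O)c(O)c3)nn2-c2ccc(Br)cc2)cc1` and compound 2 `CS(=O)(=O)c1ccc(-c2nc(SCCCOC(=O)/C=C/c3ccc(O)c(O)c3)nn2-c2ccc(F)cc2)cc1` share one core; compound 3 `CC(=O)Oc1ccc(/C=C/C(=O)NCCCSc2nc(-c3ccc(S(C)(=O)=O)cc3)n(-c3ccc(Br)cc3)n2)cc1OC(C)=O` and the still unmeasured compound 4 `CC(=O)Oc1ccc(/C=C/C(=O)NCCCSc2nc(-c3ccc(S(C)(=O)=O)cc3)n(-c3ccc(F)cc3)n2)cc1OC(C)=O` share another. Compound 3 differs from compound 1 in more than one place, and the difference between the two cores is not broken down here.

In a functional assay on A549 cells (Homo sapiens) for antiproliferative activity, read by MTT assay, with a stated time of 72 h (on this read-out higher numbers stand for weaker inhibition and lower numbers for stronger inhibition), compound 1 gives 11200 nM, and compound 2 gives 9520 nM. The change between them is fluoro in place of bromo on an aromatic carbon, and it produced a 1.2-fold lower number from compound 1 to compound 2 (0.07 log units; within the scatter), so the two values sit together. Compound 3 gives 23300 nM in this assay, the highest number of the three, beyond the scatter from both compound 1 and compound 2.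

Compound 4 arises from compound 3 by fluoro in place of bromo on an aromatic carbon, the same change, in the same place, as that from compound 1 to compound 2. In this assay, among the compounds with values here, the step expected is a 1.2-fold lower number from compound 3 to compound 4 (0.07 log units; within the scatter), kept small because a 1.2-fold lower number from compound 1 to compound 2 (0.07 log units; within the scatter) stayed within the scatter, with only one such pair to go on. Compound 4 is therefore estimated at 20000 nM, with 10000 nM and 40000 nM as the ends of the expected range.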

Compound 4, half-maximal inhibitory concentration: 21800 nM
Beside the measured number, compound 4's estimate is 1.1-fold (0.04 log units) below it; low and high end bracket the measured number.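

Carried to the second core, fluoro in place of bromo on an aromatic carbon gives a 1.1-fold lower number from compound 3 to compound 4 (0.03 log units; within the scatter) in this assay, so the 4-bromophenyl to 4-fluorophenyl swap stays within the scatter on this core as well. Set side by side, the two steps agree: the same change on two cores in this assay, a 1.2-fold lower number (0.07 log units; within the scatter) from compound 1 to compound 2 and a 1.1-fold lower number (0.03 log units; within the scatter) from compound 3 to compound 4, 1.1-fold (0.04 log units) apart, within the scatter of two such steps

Within the data shown here, this agreement rests on one change, two cores and one cell line, and with both steps within the scatter it shows only that this swap has no readable effect in either pair, not that a larger step would carry over from one core to the other.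

Open, as far as these compounds go, is how other groups in that place would read, for example an amine, a nitrile or a methoxy group. Also open, from the compounds shown here alone, is what separates the two cores, where an amide with free hydroxyl groups or an ester with acetyl groups would divide the linker difference from the difference in the hydroxyl groups, and a longer chain would test the linker itself.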